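Swapping neopentyl for phenyl in a cytotoxicity screen

A few compounds are considered here, and "the series" means these few. Any claim that something is new, unique, unknown or untested is made for them only; others in the source may bear on it.

The series shares one core, shown here as compound 1 `CCS(=O)(=O)Nc1ccc2c(c1)S(=O)(=O)N=C(c1c(O)c(-c3cccs3)nn(CCC(C)C)c1=O)N2` and compound 2 `CC(C)(C)CCn1nc(-c2cccs2)c(O)c(C2=NS(=O)(=O)c3cc(NS(C)(=O)=O)ccc3N2)c1=O`. In an ADME assay on Huh-7 cells (Homo sapiens) for cytotoxicity, with a stated time of 72 h (on this read-out higher numbers stand for lower toxicity in this test and lower numbers for higher toxicity in this test), compound 1 gives > 33000 nM, which is a limit of the test rather than a number. In this assay compound 2 gives > 1000 nM, again a limit and not a number. Among the measured compounds shown here, compound 2 therefore stands at the limit of > 1000 nM in this assay, at which 1 of the 2 values shown sits, while the other value shown sits at the limit of > 33000 nM in this assay, at which 1 of the 2 values shown sits; with both values being limits, nothing can be said about a difference between the two compounds, and no step between measured compounds is available.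

The new compound 3 `CS(=O)(=O)Nc1ccc2c(c1)S(=O)(=O)N=C(c1c(O)c(-c3cccs3)nn(Cc3ccccc3)c1=O)N2` differs from compound 2 in one place: phenyl in place of neopentyl on a saturated chain carbon bound to an aromatic nitrogen. For the measured compounds named here, no measured step guides this change. Since compound 2 shows > 1000 nM as a limit, compound 3 is expected to remain at or beyond the same limit, with no change beyond the scatter in this assay expected from compound 2 to compound 3 a step that the limit leaves unreadable from compound 2 to compound 3. Compound 3 is thus estimated to read 10000 nM, within a range from 1000 nM to 50000 nM, most likely again as a limit.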

Compound 3, half-maximal cytotoxic concentration: > 1000 nM
Compound 3 ended at the assay's limit; the forecaster's own chance of this, stated with the estimate: 75%; the middle value lies beyond the limit too.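

In this assay compound 2 and compound 3 both rest at a limit and not at a number, so no step can be read from the change of neopentyl to phenyl. The compounds shown leave open where the half-maximal cytotoxic concentration of either compound actually lies, and whether that change moves it at all.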